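A few compounds are considered here, and "the series" means these few. Any claim that something is new, unique, unknown or untested is made for them only; others in the source may bear on it.

Of the compounds shown here, two carry measured values so far. Compound 1 `N#Cc1cnc(NCc2cnccc2C(F)(F)F)cc1N[C@H]1C[C@H](O)C1` bears 3-hydroxycyclobutyl on the aromatic nitrogen. In an assay on isolated protein for inhibition of protein kinase C delta type (Homo sapiens), read by TR-FRET, with a stated time of 2 h (a higher number here means a weaker inhibitor, a lower number a stronger inhibitor), compound 1 returns only the assay limit > 10000 nM. Compound 2 `CO[C@H]1CC[C@H](Nc2cc(NCc3cnccc3C(F)(F)F)ncc2C#N)CC1` carries 4-methoxycyclohexyl in that place. In this assay compound 2 likewise returns only the assay limit > 10000 nM. The step that the two limits leave unreadable from compound 1 to compound 2 is therefore unreadable in size and direction. Compound 2 thus stands at the limit, as the evidence the limit of > 10000 nM in this assay, at which 2 of the 2 values shown sit, records for both values shown.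

Compound 3 `N#Cc1cnc(NCc2cnccc2C(F)(F)F)cc1NC[C@H]1CC[C@@H](O)CC1` differs from compound 2 by (4-hydroxycyclohexyl)methyl in place of 4-methoxycyclohexyl on a nitrogen on an aromatic ring. Among the compounds with values here, no measured step bears on this change directly. Within the data shown here, the only measured step, a step that the two limits leave unreadable from compound 1 to compound 2, sits between two limits and gives no size for any change on this nitrogen. With both measured members resting at the limit, compound 3 is expected to rest there too, and no step beyond the scatter is expected in this assay. The estimate for compound 3 is 12000 nM, with a range from 4000 nM to 40000 nM. The expected step is a step that the limit leaves unreadable from compound 2 to compound 3, most likely reported again as a limit.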

Compound 3, half-maximal inhibitory concentration: 500 nM
Beside the measured number, compound 3's estimate is 24-fold (1.38 log units) above it; the measured number lies below the stated range.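

The substituent on the nitrogen on the aromatic ring can move the value in this assay, something the two earlier compounds could not show: the change from 4-methoxycyclohexyl to (4-hydroxycyclohexyl)methyl gives an at least 20-fold lower number from compound 2 to compound 3 (1.30 log units; beyond the scatter). The same group in place of 3-hydroxycyclobutyl gives an at least 20-fold lower number from compound 1 to compound 3 (1.30 log units; beyond the scatter), so a hydroxyl-bearing substituent on this nitrogen does not by itself decide the outcome, since compound 1 carries one as well and still rests at the limit. Within the data shown here, compound 3 is the only member with a value inside the range of the assay, and both of its steps are lower bounds on the size of the change, with the other two members resting here: the limit of > 10000 nM in this assay, at which 2 of the 3 values shown sit.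

The step from compound 2 to compound 3 alters the substituent in more than one respect, exchanging methoxy for hydroxy and ring for ring-plus-methyl, and the compounds shown do not separate these, which (4-methoxycyclohexyl)methyl and 4-hydroxycyclohexyl on the same nitrogen would do. Also open, going by these compounds, is how far this position tolerates other ends to the chain, such as an amine, a carboxylic acid or a longer chain carrying the hydroxyl.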